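The source may hold more compounds than are shown below. What is called first, only, known or untested is meant among the compounds shown, and "the series" means these compounds.

Measured in an assay on HEK293 cells for displacement of a labelled ligand from Melanocortin receptor 4 (Homo sapiens); on this read-out lower numbers stand for stronger inhibition and higher numbers for weaker inhibition:
compound 1 `CCC(C)[C@H](N)c1cc(C(F)(F)F)ccc1N1CCN(C(=O)CCc2ccc(Cl)cc2)CC1`: 86 nM
compound 2 `Cc1cccc(CCC(=O)N2CCN(c3ccc(C(F)(F)F)cc3[C@@H](N)CC(C)C)CC2)c1`: 2100 nM
compound 3 `COc1ccc(CCC(=O)N2CCN(c3ccc(C(F)(F)F)cc3[C@@H](N)CC(C)C)CC2)cc1`: 350 nM

Compound 3 sits second highest of the three numbers in this assay; compound 1 gives a lower number and compound 2 a higher one. Compound 4 `COc1cc(OC)c(OC)cc1CCC(=O)N1CCN(c2ccc(C(F)(F)F)cc2[C@@H](N)CC(C)C)CC1` differs from compound 3 by 2,4,5-trimethoxyphenyl in place of 4-methoxyphenyl on a saturated chain carbon, two bonds along the chain from a carbonyl carbon. Within the data shown here, one measured step bears on this position: a 6.0-fold lower number from compound 2 to compound 3 (0.78 log units; beyond the scatter). Among the measured compounds shown here, that step shows the group on this chain carbon matters, but no measured compound carries more than one substituent on that ring, so the two added methoxy groups have no direct precedent. In this assay a step of a 1.4-fold higher number from compound 3 to compound 4 (0.15 log units; within the scatter) is expected, with wide uncertainty. Compound 4 is estimated at 500 nM, within 120 nM to 2000 nM.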

Compound 4, inhibition constant: 6100 nM
Beside the measured number, compound 4's estimate is 12-fold (1.09 log units) below it, outside the stated range (above it).
By their numbers in this assay, from the lowest: compound 1; then compound 3; then compound 2; then compound 4.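

In this assay the gain seen for 4-methoxyphenyl over 3-methylphenyl does not extend to more methoxy groups on the ring: a 17-fold higher number from compound 3 to compound 4 (1.24 log units; beyond the scatter) reverses it and goes further, and a 2.9-fold higher number from compound 2 to compound 4 (0.46 log units; beyond the scatter) puts 2,4,5-trimethoxyphenyl past even 3-methylphenyl. This chain position therefore responds strongly to ring substitution, and not in one direction. Nothing at hand accounts for the loss.

Which of the added methoxy groups carries the step stays open. So does whether a ring with two methoxy groups, or with hydroxyl groups in their place, would behave the same.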